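Moving the methoxy group on the styryl ring of compound 2

The compounds below may be only part of what the source reports. "The series", "measured", "known", "first", "only" and "open" are said of these compounds alone.

Measured compounds:
Compound 1 `COc1cc2nc(/C=C/c3ccccc3F)nc(N3CCC(CCNS(N)(=O)=O)CC3)c2cc1OC` — 211 nM
Compound 2 `COc1ccccc1/C=C/c1nc(N2CCC(CCNS(N)(=O)=O)CC2)c2cc(OC)c(OC)cc2n1` — 302 nM

Both compounds were tested in an assay on cells for inhibition of Ectonucleotide pyrophosphatase/phosphodiesterase family member 1 (Homo sapiens), with a stated time of 60 min; on this read-out higher numbers stand for weaker inhibition and lower numbers for stronger inhibition. Compound 1 gives 211 nM and compound 2 gives 302 nM. The one shift between them is a 1.4-fold higher number from compound 1 to compound 2 (0.16 log units; within the scatter), a methoxy in place of fluoro on an aromatic carbon, so the two compounds cannot be told apart on these numbers. Compound 2 has the higher of the two numbers, but its nearest neighbour, compound 1, lies within the scatter of it.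

Compound 3 `COc1ccc(/C=C/c2nc(N3CCC(CCNS(N)(=O)=O)CC3)c3cc(OC)c(OC)cc3n2)cc1` has not yet been tested. It keeps every atom of compound 2 and differs only in the arrangement: 4-methoxyphenyl in place of 2-methoxyphenyl on a double-bonded chain carbon bound to a double-bonded chain carbon. Within the data shown here, no measured pair shows what moving the methoxy group around the ring does; the only measured step exchanges one group for another at the same spot and stays within the scatter. With nothing pointing either way, the expectation for a 1.0-fold lower number from compound 2 to compound 3 (0.00 log units; within the scatter) in this assay is a step no larger than the scatter. Compound 3 is therefore estimated at 300 nM, with a range from 120 nM to 800 nM.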

Compound 3, inhibition constant: 231 nM
Estimate against measurement, compound 3: 1.3-fold (0.11 log units) above; the range from low to high includes it.
By their numbers in this assay, from the lowest: compounds 1, 3 and 2 (each within the scatter of the next).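

Within this assay moving the methoxy group from 2-methoxyphenyl to 4-methoxyphenyl, with the same atoms joined differently, gives a 1.3-fold lower number from compound 2 to compound 3 (0.12 log units; within the scatter) and so leaves the number inside the normal spread of repeat measurements. Replacing 2-fluorophenyl with 4-methoxyphenyl at the same place gives a 1.1-fold higher number from compound 1 to compound 3 (0.04 log units; within the scatter) so a change of both the group and its arrangement also cannot be told from noise, and the three compounds cannot be put in order. No separate measurement is available to explain why these values stay so close.

As far as these compounds go, what remains open is whether this tolerance extends to groups of a different kind on the phenyl ring, such as a hydroxyl, an amine or a carboxylic acid, which could show whether this part of the molecule can shift the number beyond the scatter. The compounds shown also keep the double-bonded chain, the shared core and the piperidine side chain unchanged, so they leave open what a longer chain in place of the double-bonded link would do.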